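A few compounds are considered here, and "the series" means these few. Any claim that something is new, unique, unknown or untested is made for them only; others in the source may bear on it.

Measured in a functional assay on MCF7 cells (Homo sapiens) for antiproliferative activity, with a stated time of 48 h; on this read-out higher numbers stand for weaker inhibition and lower numbers for stronger inhibition:
- compound 1 `CC(C)(C)c1ccc(CNC(=O)NC(=O)CCl)cc1`: 2800 nM
- compound 2 `CCNC(=O)NCc1ccc(C(C)(C)C)cc1`: > 100000 nM (a limit of the assay, not a number)
- compound 3 `CC(C)(C)c1ccc(CNC(=O)CCCl)cc1`: 67000 nM

Within the data shown here, of the two true numbers, compound 3 holds the higher one and so shows the weaker inhibition, with compound 1 the only other number to compare. The next candidate is compound 4 `C=CC(=O)NCc1ccc(C(C)(C)C)cc1`, which has vinyl in place of 2-chloroethyl on a carbonyl carbon.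

Among the measured compounds shown here, no measured step makes this exact swap, but two changes touch the same carbonyl carbon. The first, a 24-fold higher number from compound 1 to compound 3 (1.38 log units; beyond the scatter), is large and shows that this site can matter. However, it removes ((chloromethyl)carbonyl)amino, which compound 4 does not regain. The second, an at least 1.4-fold lower number from compound 2 to compound 3 (0.17 log units; that floor lies within the scatter), has a floor within the scatter. Compound 4 keeps the plain amide of compound 3, so little movement is expected in this assay, perhaps slightly towards a lower number.

The step expected here is a 1.3-fold lower number from compound 3 to compound 4 (0.13 log units; within the scatter), which stays within the scatter. Compound 4 is estimated at 50000 nM, with an expected range of 20000 nM to 100000 nM.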

Compound 4, half-maximal inhibitory concentration: > 100000 nM
Compound 4: no number, only a limit (the forecaster's own chance of this, stated with the estimate: 20%); middle value at least 2.0-fold (0.30 log units) away from the limit.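

Compound 4 gives only a limit in this assay, not a number, and that limit is shared: the limit of > 100000 nM in this assay, at which 2 of the 4 values shown sit.

As far as these compounds go, putting vinyl in place of 2-chloroethyl gives an at least 1.4-fold higher number from compound 3 to compound 4 (0.17 log units; that floor lies within the scatter), so this swap on the carbonyl carbon brings no lower number, though the true size of the step stays unknown. Vinyl in place of ((chloromethyl)carbonyl)amino gives an at least 35-fold higher number from compound 1 to compound 4 (1.55 log units; beyond the scatter), which shows that a vinyl group does not restore the much lower number of compound 1.

The step between compound 2 and compound 4 cannot be read, as the two limits give no size. Also open, from the compounds shown here alone, is how a longer chain ending in chlorine, or an amine on the same carbonyl carbon, would read in this assay.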